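Methyl in Place of Methylsulfanyl: Expected Potency of Compound 3

The compounds below may be only part of what the source reports. "The series", "measured", "known", "first", "only" and "open" are said of these compounds alone.

Measured compounds:
compound 1, `Nc1ncnc2c1nc(O)n2Cc1ccc(Cl)cc1`: 10 uM
compound 2, `CSc1nc2c(N)ncnc2n1Cc1ccccc1`: > 10 uM

Both were tested in a functional assay (spleen, spleen) for activation, with Mus musculus as the target; a higher number here means that more compound is needed for the effect, a lower number that less compound is needed. Compound 1 gives 10 uM. For compound 2 the result is only a limit of the assay, > 10 uM, not a number. Compound 2 therefore stands at the limit of > 10 uM in this assay, at which 1 of the 2 values shown sits.

Compound 3, `Cc1nc2c(N)ncnc2n1Cc1ccccc1`, has not been measured. It differs from compound 2 in one place: methyl in place of methylsulfanyl on an aromatic carbon. Among the compounds with values here, no measured pair shows this change, so in this assay a small step is expected, probably none beyond the usual scatter, with compound 3 staying weak. Compound 3 is estimated at 20 uM, expected between 5 uM and 100 uM. The expected step is a step that the limit leaves unreadable from compound 2 to compound 3.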

Compound 3, minimum effective concentration: > 10 uM
Compound 3: only a limit was reported (the forecaster's own chance of this, stated with the estimate: 60%); the middle value does not contradict the limit.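

No step can be read from compound 2 to compound 3, because both results are limits of the assay and not numbers: the limit of > 10 uM in this assay, at which 2 of the 3 values shown sit.

The compounds shown leave open whether methyl in place of methylsulfanyl changes the concentration needed at all.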